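The source may hold more compounds than are shown below. What is called first, only, known or untested is meant among the compounds shown, and "the series" means these compounds.

In a functional assay on Raji cells (Homo sapiens) for cytotoxicity, read by MTT assay, with a stated time of 48 h (on this read-out higher numbers stand for weaker inhibition and lower numbers for stronger inhibition), compound 1 `N#Cc1ccc(Cn2c(/C=C3\SC(=S)N(CC(=O)O)C3=O)nc3ccccc32)cc1` gives 9780 nM, compound 2 `O=C(O)CN1C(=O)/C(=C/c2nc3ccccc3n2Cc2ccc(C(F)(F)F)cc2)SC1=S` gives 18800 nM and compound 3 `O=C(O)CN1C(=O)/C(=C/c2nc3ccccc3n2Cc2ccccc2F)SC1=S` gives 1230 nM, the lowest number of the three. Compound 4 `O=C(O)CN1C(=O)/C(=C/c2nc3ccccc3n2Cc2cccc(F)c2)SC1=S` differs from compound 3 by 3-fluorophenyl in place of 2-fluorophenyl on a saturated chain carbon bound to an aromatic nitrogen. Going by the values given here, no measured step makes this exchange alone. The closest evidence is an 8.0-fold lower number from compound 1 to compound 3 (0.90 log units; beyond the scatter) and a 15-fold lower number from compound 2 to compound 3 (1.18 log units; beyond the scatter), each replacing the whole substituted phenyl group, while a 1.9-fold higher number from compound 1 to compound 2 (0.28 log units; within the scatter) stays within the scatter. Those steps show that this group can shift the number substantially, so a modest rise is expected in this assay, though none beyond the scatter remains possible. The expected change is a 2.3-fold higher number from compound 3 to compound 4 (0.36 log units; beyond the scatter). For compound 4 the estimated value is 2800 nM, with an expected range of 800 nM to 10000 nM.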

Compound 4, half-maximal inhibitory concentration: 13300 nM
Beside the measured number, compound 4's estimate is 4.8-fold (0.68 log units) below it; the measured number lies above the stated range.
By their numbers in this assay, from the lowest: compound 3; then compounds 1, 4 and 2 (each within the scatter of the next).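

In this assay, moving the fluorine from 2-fluorophenyl to 3-fluorophenyl, with the same atoms joined differently, gives an 11-fold higher number from compound 3 to compound 4 (1.03 log units; beyond the scatter) and so is by itself a large change on this saturated chain carbon bound to an aromatic nitrogen. Compound 4 does not stand apart from the other two, with a 1.4-fold lower number from compound 2 to compound 4 (0.15 log units; within the scatter) and a 1.4-fold higher number from compound 1 to compound 4 (0.13 log units; within the scatter) as the steps that link them, which leaves compound 3 alone at the low end. Nothing available here accounts for this gap.

On these data alone, it remains open whether 4-fluorophenyl, 2-chlorophenyl or 2-methoxyphenyl on that carbon would stand with compound 3 or with the others.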